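A few compounds are considered here, and "the series" means these few. Any claim that something is new, unique, unknown or untested is made for them only; others in the source may bear on it.

Measured so far in a functional assay on NCI-H23 cells (Homo sapiens) for cytotoxicity, read by sulforhodamine B assay, with a stated time of 48 h, tested at 0.01 uM; on this read-out higher numbers stand for a weaker effect at the one concentration tested and lower numbers for a stronger effect:

compound 1, `COc1cc(-c2cc(/C=C/C(=O)c3ccc(Cl)c(Cl)c3)[nH]n2)cc(OC)c1OC`: 95%
compound 2, `COc1ccc(C(=O)/C=C/c2cc(-c3cc(OC)c(OC)c(OC)c3)n[nH]2)cc1OC`: 93%

Compound 2 sits at the bottom of the two numbers shown, but the gap between the two is only a number 2 percentage points lower from compound 1 to compound 2 (within the scatter), so the two compounds are indistinguishable on this read-out; both leave most of the cells unaffected at the tested concentration.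

Compound 3, `COc1cc(C(=O)/C=C/c2cc(-c3cc(OC)c(OC)c(OC)c3)n[nH]2)cc(OC)c1OC`, differs from compound 2 in one place: methoxy in place of hydrogen on an aromatic carbon. The group enters on an aromatic carbon of a six-membered aromatic ring of carbon only, ortho to a methoxy group and meta to a large group. Within the data shown here, the single measured step, from a 3,4-dichlorophenyl to a 3,4-dimethoxyphenyl on the carbonyl carbon, reworked the same ring and gave a number 2 percentage points lower from compound 1 to compound 2 (within the scatter). Among the measured compounds shown here, both numbers lie near the top of the scale, so there is little room for movement upward, and the only precedent argues against movement downward. Accordingly a step of no change at the digits printed from compound 2 to compound 3 (within the scatter) is expected, within the scatter. Compound 3 is estimated at 93% in this assay, with a range from 83% to 101%.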

Compound 3, a percentage reported as activity, at one concentration (the size of the read-out at that concentration, not a potency): 100%
Estimate against measurement, compound 3: 7 percentage points below, within the range that was stated.
By their numbers in this assay, from the lowest: compounds 2, 1 and 3 (each within the scatter of the next).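

In this assay, methoxy in place of hydrogen on an aromatic carbon of the six-membered aromatic ring of carbon only that carries the carbonyl gives a number 7 percentage points higher from compound 2 to compound 3 (within the scatter), so filling this position, ortho to a methoxy group, produces no change that can be separated from the scatter. The earlier step only exchanged groups on that ring, whereas this one places a group on a carbon that carries hydrogen in both compound 1 and compound 2, and so extends the tolerated changes on this ring to an added methoxy, at least on this read-out at the one concentration tested. No measurement at hand bears on any cause behind this result.

Among these compounds, all three compounds stand near the top of the scale, so the series so far gives no sign of which change on this ring, if any, would bring the number down beyond the scatter. Whether an amine or a carboxylic acid at this position, or a longer chain such as butoxy in place of methoxy, would do so remains open, as does the behaviour of these compounds at higher concentrations.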